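Methoxy for hydroxyl on the cyclohexylmethyl amine

The source may report more compounds than this note shows. Statements on the series, on what has been measured and on what is new or still open speak of the compounds shown alone.

Compound 3 `N#Cc1cnc(NCc2cnccc2C(F)(F)F)cc1NC[C@H]1CC[C@H](O)CC1` gives 50 nM in an assay on isolated protein for inhibition of protein kinase C theta type (Homo sapiens), read by TR-FRET, with a stated time of 2 h (a lower number here means a stronger inhibitor, a higher number a weaker inhibitor), the lowest of the three numbers. Compound 2 `N#Cc1cnc(NCc2cnccc2C(F)(F)F)cc1NC[C@H]1CC[C@@H](O)CC1` gives 58 nM, and a 1.2-fold lower number from compound 2 to compound 3 (0.06 log units; within the scatter), which is what the fact that compounds 2 and 3 differ only in the configuration as drawn would lead one to expect. Compound 1 `N#Cc1cnc(NCc2cnccc2C(F)(F)F)cc1N[C@H]1C[C@@H](O)C1` gives 500 nM, and a 10-fold lower number from compound 1 to compound 3 (1.00 log units; beyond the scatter) and an 8.6-fold lower number from compound 1 to compound 2 (0.94 log units; beyond the scatter). Compound 4 `CO[C@H]1CC[C@@H](CNc2cc(NCc3cnccc3C(F)(F)F)ncc2C#N)CC1` carries 4-methoxycyclohexyl in place of 4-hydroxycyclohexyl on a saturated chain carbon bound to a nitrogen on an aromatic ring. Among the measured compounds shown here, none of the measured steps removes the hydroxyl donor or caps it, so the two ring-size steps bear only loosely; they show that this part of the molecule moves the number, not which way a capping does. A modest loss is the expected step of a 3.0-fold higher number from compound 3 to compound 4 (0.48 log units; beyond the scatter). Compound 4 is therefore estimated at 150 nM, in the range 50 nM to 450 nM.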

Compound 4, half-maximal inhibitory concentration: 70 nM
Beside the measured number, compound 4's estimate is 2.1-fold (0.33 log units) above it; measured number inside the range.
By their numbers in this assay, from the lowest: compounds 3, 2 and 4 (each within the scatter of the next); then compound 1.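

Methyl on the oxygen of the (4-hydroxycyclohexyl)methyl amine leaves the number unmoved (a 1.4-fold higher number from compound 3 to compound 4 (0.15 log units; within the scatter)) (a 1.2-fold higher number from compound 2 to compound 4 (0.08 log units; within the scatter)), so in this assay the hydrogen-bond donor of 4-hydroxycyclohexyl is not required at this place. The advantage over the 3-hydroxycyclobutyl of compound 1 persists with the methoxy group (a 7.1-fold lower number from compound 1 to compound 4 (0.85 log units; beyond the scatter)). Nothing at hand explains why the methyl is accepted.

Still open, from the compounds shown here alone, is whether a larger ether such as ethoxy or benzyloxy, or an amine or carboxylic acid in place of methoxy, would hold the number. Also open, going by these compounds, is whether the mirror-image configuration of compound 4 would match it, as compound 2 and compound 3 match each other.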